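The source may report more compounds than this note shows. Statements on the series, on what has been measured and on what is new or still open speak of the compounds shown alone.

Values in an ADME assay on HeLa cells (Homo sapiens) for cytotoxicity, read by LDH release, with a stated time of 24 h; a lower number here means a stronger inhibitor, a higher number a weaker inhibitor:
- compound 1 `COCCOCCOCCOCc1ccc2c(Br)cc(Br)c(O)c2n1`: 100000 nM
- compound 2 `C#CCNCc1ccc2c(Br)cc(Br)c(O)c2n1`: > 25000 nM (a limit)
- compound 3 `CC(C)(C)OC(=O)N1CCN(Cc2ccc3c(Br)cc(Br)c(O)c3n2)CC1`: > 100000 nM (a limit)

Compound 2 has no number, only the limit > 25000 nM. Compound 3 is also reported only as a limit, > 100000 nM. Among the measured compounds shown here, compound 1 is the one member of the series with a number, 100000 nM. For the measured compounds named here, no two measured compounds differ in a single place, so no measured step is available as a guide.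

Compound 4 `OCc1ccc2c(Br)cc(Br)c(O)c2n1` keeps the shared core and carries hydroxy in place of propargylamino on a saturated chain carbon bound to an aromatic carbon. In this assay no change beyond the scatter is expected, in either direction. This expectation rests on compound 1 , which reads 100000 nM. It also rests on the two limits, neither of which points to a low value. The expected step that the limit leaves unreadable from compound 2 to compound 4 is therefore small. For compound 4 the estimated value is 40000 nM, with an expected range of 15000 nM to 100000 nM.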

Compound 4, half-maximal inhibitory concentration: > 100000 nM
Compound 4 was reported as a limit; the forecaster's own chance of this, stated with the estimate: 55%; middle value at least 2.5-fold (0.39 log units) from the limit.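

In this assay, compound 2 and compound 4 are both reported only as limits, so no step can be read between them. The compounds shown leave open what numerical values these two compounds have, and whether hydroxy in place of propargylamino shifts the value at all.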